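The source may report more compounds than this note shows. Statements on the series, on what has been measured and on what is new or still open speak of the compounds shown alone.

In an ADME assay on microsomes from liver (Rattus norvegicus) for metabolic stability, read by LC-MS, using NADPH, with stated times of 10 min and 60 min (a lower number here means slower removal, a higher number faster removal of the compound), compound 1 `CCN1CCN(c2cc(CN(C)[C@H]3CCCc4cccnc43)nc(C)n2)CC1` gives 2180 mL/min/kg, which is a very fast removal. Compound 2 `Cc1nc(CN(C)[C@H]2CCCc3cccnc32)cc(N2C[C@@H](C)N(C)[C@@H](C)C2)n1` carries 3,4,5-trimethylpiperazin-1-yl on an aromatic carbon of the shared core, where compound 1 has 4-ethylpiperazin-1-yl. Compound 2 stands at > 497 mL/min/kg, which is a limit and not a number.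

Compound 3 `Cc1nc(CN(C)[C@H]2CCCc3cccnc32)cc(N2CCN3CCC[C@H]3C2)n1` changes this same group again: a group of 9 heavy atoms (7 carbon, 2 nitrogen; one five-membered non-aromatic ring with 1 hetero atom, one six-membered non-aromatic ring with 2 hetero atoms) in place of a group of 9 heavy atoms (7 carbon, 2 nitrogen; one six-membered non-aromatic ring with 2 hetero atoms), on an aromatic carbon. The group that enters keeps a six-membered non-aromatic ring and adds a five-membered one. Among the compounds with values here, the only measured step that bears on this change is a step that the limit leaves unreadable from compound 1 to compound 2. It offers no size to carry forward, so no direction can be expected from it. The expectation therefore rests on compound 1 at 2180 mL/min/kg and leaves a wide range open. The step expected here is a step that the limit leaves unreadable from compound 2 to compound 3, and its size is only loosely estimated. For compound 3 the estimated clearance is 1000 mL/min/kg, with an expected range from 350 mL/min/kg to 3000 mL/min/kg.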

Compound 3, clearance: > 497 mL/min/kg
Compound 3 was reported as a limit; the forecaster's own chance of this, stated with the estimate: 35%; the middle value does not contradict the limit.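

In this assay compound 3 gives > 497 mL/min/kg which is a limit and not a number, so no new step can be read among compound 1, compound 2 and compound 3: the limit of > 497 mL/min/kg in this assay, at which 2 of the 3 values shown sit. Going by these compounds, the actual clearance of compound 2 and compound 3 stays open, and with it how these two compare with each other and with compound 1.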